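Tetrazolyl-acetamide pyrazoles: a new aryl group on the tetrazole

The source may hold more compounds than are shown below. What is called first, only, known or untested is meant among the compounds shown, and "the series" means these compounds.

Measured so far:
compound 1, `Cc1cc(NC(=O)Cn2nnc(-c3ccccc3)n2)n(-c2ccccc2)n1`: 3020 nM
compound 2, `Cc1cc(NC(=O)Cn2nnc(-c3cc(Cl)cc(Cl)c3)n2)n(C2CCCCC2)n1`: 980 nM

In an assay on HEK293 cells for activation of Kir3.1/Kir3.2 (Homo sapiens), read by thallium flux (on this read-out lower numbers stand for an effect already at smaller amounts and higher numbers for an effect only at larger amounts of compound), compound 2 holds the lowest of the two numbers; its gap to compound 1 lies beyond the usual scatter. Compound 3, `Cc1cc(NC(=O)Cn2nnc(-c3ccc(Cl)c(C)c3)n2)n(C2CCCCC2)n1`, carries 4-chloro-3-methylphenyl in place of 3,5-dichlorophenyl on an aromatic carbon. Among the measured compounds shown here, no measured pair shows what such a swap does, so nothing in hand tells the direction. The expected step from compound 2 to compound 3 is a modest one, a 1.5-fold higher number from compound 2 to compound 3 (0.18 log units; within the scatter), toward a slightly higher number but probably within the scatter. For compound 3 the estimate is 1500 nM, with a range from 500 nM to 4500 nM.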

Compound 3, half-maximal effective concentration: 712 nM
Estimate against measurement, compound 3: 2.1-fold (0.32 log units) above, and the stated range covers the measured number.
By their numbers in this assay, from the lowest: compounds 3 and 2 (each within the scatter of the next); then compound 1.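

In this assay, 4-chloro-3-methylphenyl in place of 3,5-dichlorophenyl on the aromatic carbon of the five-membered aromatic ring with 4 nitrogen gives a 1.4-fold lower number from compound 2 to compound 3 (0.14 log units; within the scatter). This position therefore takes a methyl in place of one chlorine, with the chlorine pattern also altered, without a change that this read-out can separate from the scatter. Nothing available accounts for this result.

On these data alone, what 4-chlorophenyl or 3-methylphenyl would give at this carbon remains open, so the chlorine and the methyl cannot yet be read apart. Also open, as far as these compounds go, is how an amine or a carboxylic acid on this aryl ring would fare.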